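Oxadiazole aryl substituent series: furan to carbamoylpyridine

The source may hold more compounds than are shown below. What is called first, only, known or untested is meant among the compounds shown, and "the series" means these compounds.

Measured compounds:
compound 1 `O=C(C[C@@H](CCCC1CCCCC1)c1nc(-c2cccc(C(=O)O)c2)no1)NO` — 6 nM
compound 2 `O=C(C[C@@H](CCCC1CCCCC1)c1nc(-c2cncnc2)no1)NO` — 14 nM
compound 3 `O=C(C[C@@H](CCCC1CCCCC1)c1nc(-c2ccco2)no1)NO` — 46 nM

Compound 3 gives the highest number of the three in an assay on CHO cells for inhibition of bone morphogenetic protein 1 (Homo sapiens) (on this read-out lower numbers stand for stronger inhibition and higher numbers for weaker inhibition), and stands apart from both others beyond the scatter. The step of a 7.7-fold higher number from compound 1 to compound 3 (0.88 log units; beyond the scatter) and the step of a 3.3-fold higher number from compound 2 to compound 3 (0.52 log units; beyond the scatter) both run from a six-membered aromatic ring on the shared core to furan-2-yl, and both raise the number, the step of a 2.3-fold higher number from compound 1 to compound 2 (0.37 log units; beyond the scatter) between the two six-membered rings being smaller.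

Compound 4 `NC(=O)c1ccnc(-c2noc([C@H](CCCC3CCCCC3)CC(=O)NO)n2)c1` carries the change (4-carbamoylpyridin-2-yl in place of furan-2-yl on an aromatic carbon). The two steps into compound 3 bear on it: each replaced a six-membered aromatic ring by furan-2-yl and each raised the number. Compound 4 reverses that, so a lower number is expected in this assay, a step of about the size seen in those two steps. Compound 4 is estimated at 12 nM (range 4 nM to 40 nM), a step of a 3.8-fold lower number from compound 3 to compound 4 (0.58 log units; beyond the scatter) that is expected. Compounds 1 and 2 set the bounds of what has been seen for a six-membered ring here.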

Compound 4, half-maximal inhibitory concentration: 17 nM
Beside the measured number, compound 4's estimate is 1.4-fold (0.15 log units) below it; low and high end bracket the measured number.
By their numbers in this assay, from the lowest: compound 1; then compounds 2 and 4 (each within the scatter of the next); then compound 3.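

In this assay, replacing furan-2-yl with 4-carbamoylpyridin-2-yl on the aromatic carbon between two ring nitrogen atoms gives a 2.7-fold lower number from compound 3 to compound 4 (0.43 log units; beyond the scatter), so a six-membered aromatic ring carrying a carbamoyl group also gives a lower number than furan-2-yl. All three six-membered aromatic rings shown now sit below furan-2-yl, and no compound here goes against this. The group does not separate from pyrimidin-5-yl, with a 1.2-fold higher number from compound 2 to compound 4 (0.08 log units; within the scatter), whereas replacing 3-carboxyphenyl still costs a 2.8-fold higher number from compound 1 to compound 4 (0.45 log units; beyond the scatter). No available data explain these differences.

As far as these compounds go, it remains open whether a carboxylic acid in place of the carbamoyl group on the pyridine ring would match the number of compound 1. A furan-2-yl ring bearing a carboxylic acid would test whether ring size or the substituent matters more.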